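Pyridyl nitrogen position on the anilinopyrimidine core

This account rests on a few compounds, and the source may have more. Where it says the series, first, only, none or still open, it means among the compounds named here.

Measured so far:
compound 1, `CC(=O)Nc1cccc(Nc2nccc(-c3ccccn3)n2)c1`, 300 nM
compound 2, `CCOC(=O)c1cccc(Nc2nccc(-c3ccccn3)n2)c1`, 3000 nM

In a functional assay for inhibition, with Homo sapiens as the target (a higher number here means a weaker inhibitor, a lower number a stronger inhibitor), compound 1 gives 300 nM, the lowest number of the two measured. Among the compounds with values here, compound 2 sits above it: a 10-fold higher number from compound 1 to compound 2 (1.00 log units; beyond the scatter), the only measured step in the set, and it concerns the group on the anilino ring, not the heteroaryl on the shared core.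

Compound 3, `CC(=O)Nc1cccc(Nc2nccc(-c3cccnc3)n2)c1`, is not yet measured. It differs from compound 1 in one place: pyridin-3-yl in place of pyridin-2-yl on an aromatic carbon. Within the data shown here, no measured pair changes this part of the molecule, so the step from compound 1 to compound 2 does not bear on it; it only shows that the anilino substituent is sensitive to change, which says nothing about the pyridyl. With nothing to anchor the direction, the working expectation for no change at the digits printed from compound 1 to compound 3 (within the scatter) is no step beyond the scatter, with a wide band either way. Compound 3 is therefore estimated at 300 nM in this assay, expected to lie between 80 nM and 1500 nM.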

Compound 3, half-maximal inhibitory concentration: 3600 nM
The estimate for compound 3 lay 12-fold (1.08 log units) below the measured number, and the stated range ends below it.
By their numbers in this assay, from the lowest: compound 1; then compounds 2 and 3 (each within the scatter of the next).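

In this assay the heteroaryl on the shared core turns out to be as sensitive to change as the anilino substituent, with a 12-fold higher number from compound 1 to compound 3 (1.08 log units; beyond the scatter) for a swap that only moves the ring nitrogen. Pyridin-2-yl and pyridin-3-yl have the same heavy atoms and the same counts of hydrogen-bond donors and acceptors, and both sit on the same aromatic carbon, so those counts do not separate compound 1 from compound 3 and only the location of the pyridyl nitrogen differs between them. Nothing available on these compounds bears on why this location carries such weight.

The compounds shown do not settle whether pyridin-2-yl is favoured by its ring nitrogen or whether pyridin-3-yl is simply unfavourable, a question that pyridin-4-yl and a plain phenyl on the same carbon would address. Also open, from the compounds shown here alone, is whether the rise seen with pyridin-3-yl holds when acetamido on the anilino ring is replaced, for example by ethoxycarbonyl, an amine or a carboxylic acid.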